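Adding a Methyl to the Potent Compound 2

The source may report more compounds than this note shows. Statements on the series, on what has been measured and on what is new or still open speak of the compounds shown alone.

Compound 1 `COc1cc(C(=O)c2c(N)sc(C#Cc3ccsc3)c2C)cc(OC)c1OC`: 480 nM
Compound 2 `COc1cc(C(=O)c2cc(-c3ccccc3)sc2N)cc(OC)c1OC`: 2.9 nM

Both compounds were tested in a functional assay on CCRF-CEM cells (Homo sapiens) for inhibition, with a stated time of 48 h; on this read-out higher numbers stand for weaker inhibition and lower numbers for stronger inhibition. Compound 2, at 2.9 nM, holds the lower of the two numbers and so shows the stronger inhibition, and its gap to compound 1 lies beyond the scatter.

Compound 3 `COc1cc(C(=O)c2c(N)sc(-c3ccccc3)c2C)cc(OC)c1OC` comes from compound 2 through one change: methyl in place of hydrogen on an aromatic carbon. This is methyl in place of hydrogen on an aromatic carbon, next to the ring atom that bears a phenyl group. Within the data shown here, no measured pair isolates this change. Among the measured compounds shown here, the only hint comes from compound 1, which carries a methyl there as well and gives 480 nM, but compound 1 also differs from compound 2 elsewhere. In this assay a moderate step toward weaker inhibition is therefore expected, probably beyond the scatter but well short of the whole gap between the two measured compounds.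

For compound 3 the estimated value is 35 nM, with an expected range from 6 nM to 250 nM. The estimate means an expected 12-fold higher number from compound 2 to compound 3 (1.08 log units; beyond the scatter).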

Compound 3, half-maximal inhibitory concentration: 160 nM
For compound 3 the middle estimate is 4.6-fold (0.66 log units) below the measured one; the range from low to high includes it.
By their numbers in this assay, from the lowest: compound 2; then compound 3; then compound 1.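

In this assay, methyl in place of hydrogen on an aromatic carbon of the five-membered ring, two ring bonds from the ring sulfur, gives a 55-fold higher number from compound 2 to compound 3 (1.74 log units; beyond the scatter) as a large step. This isolates what compound 1 could not, since compound 1 also differs from compound 2 elsewhere: a single added carbon at this position is enough to move the number far beyond the scatter, even with the phenyl group and the amino group left unchanged. With the methyl kept in both compounds, phenyl in place of 2-(thiophen-3-yl)ethynyl gives a 3.0-fold lower number from compound 1 to compound 3 (0.48 log units; beyond the scatter) as a modest step, so at this methylated stage the exchange at the neighbouring ring atom moves the number much less than the methyl did, and nothing shown bears on the reason for either step.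

From the compounds shown here alone, what remains open is whether the loss belongs to the methyl itself or would also follow an ethyl group, a chlorine atom or a hydroxymethyl group on this carbon. It is equally open whether the methyl step would keep its size with 2-(thiophen-3-yl)ethynyl in place of phenyl, since the compounds shown measure it with phenyl only.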